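A methyl-to-methoxyphenyl change on a weak inhibitor

The compounds below may be only part of what the source reports. "The series", "measured", "known", "first", "only" and "open" are said of these compounds alone.

Compound 1 `CCCc1nn(C)c2c(NCc3ccc(F)cc3)nc(/C=C/c3cccnc3)nc12`: 940000 nM
Compound 2 `CCCc1nn(C)c2c(NCc3ccc(F)cc3)nc(/C=C/c3ccc[n+]([O-])c3)nc12`: < 40000 nM
Compound 3 `CNc1nc(/C=C/c2ccccc2)nc2ccsc12`: > 1000000 nM

In a functional assay on L02 cells (Homo sapiens) for inhibition, read by Griess assay, with stated times of 1 h and 24 h (a lower number here means a stronger inhibitor, a higher number a weaker inhibitor), compound 1 gives 940000 nM. Compound 2 gives only a limit, < 40000 nM. Compound 3 gives only a limit as well, > 1000000 nM, and so it stands at the limit of > 1000000 nM in this assay, at which 1 of the 3 values shown sits. Among the compounds with values here, the single measured step, an at least 23-fold lower number from compound 1 to compound 2 (1.37 log units; beyond the scatter), concerns a group on a double-bonded chain carbon, not the ring nitrogen changed here, so no measured step bears on the change 4-methoxyphenyl in place of methyl on a nitrogen on an aromatic ring that turns compound 3 into compound 4 `COc1ccc(Nc2nc(/C=C/c3ccccc3)nc3ccsc23)cc1`. Lacking any guide, compound 4 is expected to sit close to compound 3, an estimated step of an at least 1.4-fold lower number from compound 3 to compound 4 (0.15 log units; that floor lies within the scatter). Compound 4 is estimated at 700000 nM, with a range from 100000 nM to 3000000 nM.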

Compound 4, half-maximal inhibitory concentration: > 1000000 nM
Compound 4 was reported as a limit; the forecaster's own chance of this, stated with the estimate: 50%; middle value at least 1.4-fold (0.15 log units) from the limit.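

Within the data shown here, compound 3 and compound 4 are both reported only as limits, so no step between them can be read. The compounds shown leave open whether 4-methoxyphenyl in place of methyl on that nitrogen changes inhibition at all.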